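Replacing the acetyl of compound 3 with phenyl

The compounds below may be only part of what the source reports. "The series", "measured", "known", "first", "only" and "open" are said of these compounds alone.

Of the compounds shown here, three sharing one core have been measured in a functional assay on the whole organism (strain Wistar) for inhibition, with Rattus norvegicus as the target, read by paw edema, with a stated time of 30 min, at a dose of 50 mg/kg by the oral route; a lower number here means less inhibition, a higher number more inhibition at the dose given (going by the name of the read-out). Compound 1 `Fc1ccc(C2=NN(c3ccccc3)C(c3cn(-c4ccccc4)nc3-c3ccc(Cl)c(Cl)c3)C2)cc1` gives 44.7%. Compound 2 `O=CN1N=C(c2ccc(Cl)cc2)CC1c1cn(-c2ccccc2)nc1-c1ccc(Cl)c(Cl)c1` gives 35.1%, and compound 3 `CC(=O)N1N=C(c2ccc(Cl)cc2)CC1c1cn(-c2ccccc2)nc1-c1ccc(Cl)c(Cl)c1` gives 45.7%. Compound 3 stands highest of the three numbers: compound 1 is within the scatter of it, and compound 2 lies beyond the scatter below it. Going by the values given here, the only single-point step measured, a number 10.6 percentage points higher from compound 2 to compound 3 (beyond the scatter), concerns the group on the carbonyl carbon.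

Compound 4 `Clc1ccc(C2=NN(c3ccccc3)C(c3cn(-c4ccccc4)nc3-c3ccc(Cl)c(Cl)c3)C2)cc1` has not yet been measured in this assay. It differs from compound 3 in one place: phenyl in place of acetyl on an amine nitrogen in a ring. Among the compounds with values here, no measured step swaps an acetyl for a phenyl on that amine nitrogen in a ring, so the one recorded step bears on it only indirectly. What can be said is that compound 1, which also carries a phenyl on that nitrogen, gives 44.7%, a number within the scatter of compound 3. The step from compound 3 to compound 4 is therefore expected to be small, and the expected change is a number 1.7 percentage points lower from compound 3 to compound 4 (within the scatter). Compound 4 is estimated at 44%, with a range from 33% to 55%.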

Compound 4, a percentage reported as inhibition, in the whole organism at one dose (the size of the read-out at that dose, not a potency): 45.7%
Compound 4: the middle estimate sits 1.7 percentage points below what was measured; the range from low to high includes it.
By their numbers in this assay, from the lowest: compounds 2, 1, 3 and 4 (each within the scatter of the next, the first and the last beyond it).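

In this assay, the swap at this amine nitrogen in a ring gave no change at the digits printed from compound 3 to compound 4 (within the scatter) even though phenyl, with its six-membered aromatic ring and no hydrogen-bond acceptor, entered where acetyl, with no ring and one hydrogen-bond acceptor, had stood, so at this dose the carbonyl of the acetyl is not needed to hold the number. Formyl now stands apart from both other groups at this nitrogen, since the change to phenyl gave a number 10.6 percentage points higher from compound 2 to compound 4 (beyond the scatter) and so matched in size the earlier step from formyl to acetyl. With phenyl on that nitrogen, the exchange on the aromatic carbon gave a number 1 percentage points higher from compound 1 to compound 4 (within the scatter) and thus did not separate chloro from fluoro in this read-out. Nothing given here accounts for these results.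

As far as these compounds go, it remains open how an amine, a carboxylic acid or a longer chain on that nitrogen would read in this assay at the same dose. From the compounds shown here alone, whether compound 3 and compound 4 would also stay level at other doses or at other times also remains open.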